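Shortening the side chain of compound 2

A few compounds are considered here, and "the series" means these few. Any claim that something is new, unique, unknown or untested is made for them only; others in the source may bear on it.

- compound 1 `CCCCCN(Cc1ccc(C(=O)NO)cc1)c1ncc(-c2ccc(C)cc2)s1` gives 7020 nM
- compound 2 `Cc1ccc(-c2cnc(N(Cc3ccc(C(=O)NO)cc3)CC(C)C)s2)cc1` gives 7420 nM

For the measured compounds named here, both values come from a functional assay on HepG2 cells (Homo sapiens) for antiproliferative activity, read by MTT assay, with a stated time of 48 h (a higher number here means a weaker inhibitor of growth, a lower number a stronger inhibitor of growth), and are the only numbers so far. On them, compound 2 stands level with compound 1 (a 1.1-fold higher number from compound 1 to compound 2 (0.02 log units; within the scatter)) and neither can be ranked above the other.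

Compound 3 `CCN(Cc1ccc(C(=O)NO)cc1)c1ncc(-c2ccc(C)cc2)s1` keeps the shared core and changes one group (methyl in place of isopropyl on a saturated chain carbon bound to a nitrogen on an aromatic ring) in a single move: methyl in place of isopropyl on a saturated chain carbon bound to a nitrogen on an aromatic ring. Cut one bond further out, the same change reads isobutyl to ethyl.

Going by the values given here, only one measured step bears on this: a 1.1-fold higher number from compound 1 to compound 2 (0.02 log units; within the scatter) at the same place, where isopropyl replaced butyl and the number stayed within the scatter. Among the compounds with values here, one step is thin evidence, and no ethyl compound has been measured yet. Even so, no step beyond the scatter is expected in this assay in either direction. The estimated change is a 1.1-fold lower number from compound 2 to compound 3 (0.03 log units; within the scatter) on this evidence. For compound 3 the expected value is 7000 nM with an estimated range of 3000 nM to 16000 nM in this test.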

Compound 3, concentration for 50% growth inhibition: 1120 nM
Compound 3: the middle estimate sits 6.3-fold (0.80 log units) above what was measured, and the stated range ends above it.
By their numbers in this assay, from the lowest: compound 3; then compounds 1 and 2 (each within the scatter of the next).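

In this assay, this position proves sensitive to the chain it carries: isobutyl to ethyl gives a 6.6-fold lower number from compound 2 to compound 3 (0.82 log units; beyond the scatter), and hydrogen in place of propyl on a saturated chain carbon, two bonds along the chain from a nitrogen on an aromatic ring, gives a 6.3-fold lower number from compound 1 to compound 3 (0.80 log units; beyond the scatter). For the compounds shown here, the earlier pair showed no separation between its two chains, so the ethyl chain is the first in this short series to stand clear of the others, and it does so against both of them. No evidence at hand accounts for this result.

Three chains cannot show whether the number keeps falling as the chain gets shorter, with methyl at this position, or whether ethyl is a special case among the chains. A chain ending in an amine or a carboxylic acid, or a cyclopropyl group in place of ethyl, would test whether the step depends only on chain length or also on what the chain is made of.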